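Side-chain configuration in a bis-ester platelet series

The source may report more compounds than this note shows. Statements on the series, on what has been measured and on what is new or still open speak of the compounds shown alone.

Three compounds have been run in a functional assay on cells (Platelet, Oryctolagus cuniculus) for inhibition, read by turbidimetry, with a stated time of 5 min; a lower number here means a stronger inhibitor, a higher number a weaker inhibitor. Compound 1 `CCCC[C@H]1NC(=O)c2ccccc21` gives 680000 nM in this assay. Compound 2 `CCCC[C@H](OC(=O)CN1CCCC1)c1ccccc1C(=O)O[C@H]1CO[C@H]2[C@@H]1OC[C@H]2OC(=O)c1ccccc1[C@H](CCCC)OC(=O)CN1CCCC1`, which carries two pyrrolidine acetate esters on the side chains, gives 640000 nM in this assay. Compound 3 `CCCC[C@H](OC(=O)CN1CCN(C)CC1)c1ccccc1C(=O)O[C@H]1CO[C@H]2[C@@H]1OC[C@H]2OC(=O)c1ccccc1[C@H](CCCC)OC(=O)CN1CCN(C)CC1`, with methylpiperazine acetate esters in the same places, gives 50000 nM in this assay, the lowest of the three numbers; compound 2 and compound 1 both stand higher, and both gaps lie beyond the usual scatter. Among the compounds with values here, no two measured compounds differ in only one place, so no single step can be isolated from the numbers so far.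

Compound 4 `CCCC[C@@H](OC(=O)CN1CCN(C)CC1)c1ccccc1C(=O)O[C@H]1CO[C@H]2[C@@H]1OC[C@H]2OC(=O)c1ccccc1[C@@H](CCCC)OC(=O)CN1CCN(C)CC1` has not yet been measured in this assay. It differs from compound 3 as follows: the two compounds have the same atoms and bonds and differ only in configuration as drawn: 2 of 6 stereo elements differ; a stereocentre at a saturated chain carbon is drawn S in compound 3 and R in compound 4; a stereocentre at a saturated chain carbon is drawn S in compound 3 and R in compound 4. The core stereocentres are untouched; only the two side-chain stereocentres are inverted.

Nothing in the measured set shows how a change of configuration moves the numbers in this assay. The step expected from compound 3 to compound 4 is therefore a 2.0-fold higher number from compound 3 to compound 4 (0.30 log units; within the scatter), a modest weakening with wide uncertainty in either direction. Compound 4 is accordingly estimated at 100000 nM in this assay, with a range from 20000 nM to 500000 nM.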

Compound 4, half-maximal inhibitory concentration: 270000 nM
The estimate for compound 4 lay 2.7-fold (0.43 log units) below the measured number; the range from low to high includes it.
By their numbers in this assay, from the lowest: compound 3; then compound 4; then compounds 2 and 1 (each within the scatter of the next).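

Within the data shown here, the inversion of the two side-chain stereocentres gives the first readable step: in this assay there is a 5.4-fold higher number from compound 3 to compound 4 (0.73 log units; beyond the scatter). With the methylpiperazine acetate esters and the core stereocentres held constant, the configuration drawn S at both chain carbons carries the lower number in this one pair, and the size of the step lies beyond the scatter. The change in number can be assigned to configuration alone, and to no change of group, because nothing else separates the pair: the fact that compounds 3 and 4 differ only in the configuration as drawn

Going by these compounds, the share of each stereocentre in this step stays open: both change together, and a form with one centre drawn S and the other drawn R would be needed to separate them. Also open, on these data alone, is whether the same inversion moves the number by a similar amount with the pyrrolidine acetate esters of compound 2, or with a morpholine acetate ester in the same places.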